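Does One Bromine Step Repeat on a Second Core?

The compounds below may be only part of what the source reports. "The series", "measured", "known", "first", "only" and "open" are said of these compounds alone.

Compound 1 `C/C(=N/NC(=O)c1ccc(S(N)(=O)=O)cc1)c1ccccc1`: 20100 nM
Compound 2 `C/C(=N/NC(=O)c1ccc(S(N)(=O)=O)cc1)c1ccc(Br)cc1`: 2290 nM
Compound 3 `NS(=O)(=O)c1ccc(C(=O)N/N=C\c2ccccc2)cc1`: 14900 nM

Of the compounds shown here, three have been tested in a functional assay on MCF7 cells (Homo sapiens) for antiproliferative activity, read by MTT assay; a higher number here means a weaker inhibitor, a lower number a stronger inhibitor. Compound 1 and compound 2 differ in a single place, (bromo in place of hydrogen on an aromatic carbon), and this gave an 8.8-fold lower number from compound 1 to compound 2 (0.94 log units; beyond the scatter). Compound 3 sits on a different core; the difference between the two cores is not broken down here. In this assay compound 3 and compound 1 give numbers within the scatter of each other.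

Compound 4 `NS(=O)(=O)c1ccc(C(=O)N/N=C\c2ccc(Br)cc2)cc1` awaits measurement. It differs from compound 3 by bromo in place of hydrogen on an aromatic carbon, the same change, at the same kind of place, that separates compound 1 from compound 2. Because an 8.8-fold lower number from compound 1 to compound 2 (0.94 log units; beyond the scatter) was seen once, a step of similar size is expected here, so that compound 4 is estimated at a 7.5-fold lower number from compound 3 to compound 4 (0.87 log units; beyond the scatter). Compound 4 is thus expected to give about 2000 nM, likely between 700 nM and 6000 nM.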

Compound 4, half-maximal inhibitory concentration: 1370 nM
Compound 4: the middle estimate sits 1.5-fold (0.16 log units) above what was measured; low and high end bracket the measured number.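

Putting bromo in place of hydrogen on an aromatic carbon of compound 3 gave an 11-fold lower number from compound 3 to compound 4 (1.04 log units; beyond the scatter) in this assay, a large step. Set beside the earlier step, the change carried over from one core to the other with much the same size: the same change on two cores in this assay, an 8.8-fold lower number (0.94 log units; beyond the scatter) from compound 1 to compound 2 and an 11-fold lower number (1.04 log units; beyond the scatter) from compound 3 to compound 4, 1.2-fold (0.09 log units) apart, within the scatter of two such steps. For the compounds shown here, this rests on only two cores, one place on the ring and one assay, so it does not show that the step would repeat on further cores, nor does it explain why the number falls.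

The compounds shown leave open whether another group at that place, such as chloro, methoxy or an amine, would give a step of similar size. On these data alone, whether the bromo step would also appear in other cell lines remains open too.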